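Chloro for hydrogen on compound 3: expected step

This account rests on a few compounds, and the source may have more. Where it says the series, first, only, none or still open, it means among the compounds named here.

In a functional assay on HO8910 cells (Homo sapiens) for inhibition, read by MTT assay, with a stated time of 24 h, tested at 0.1 ug/mL (on this read-out lower numbers stand for less inhibition of growth and higher numbers for more inhibition of growth at the one concentration tested), compound 1 (`O=C(CCCCC(S)CCS)NO`) is recorded as "not active" (no number reported), with no number reported. Compound 2 (`O=C(CCCCC1CCSS1)Nc1ccccc1Cl`) gives 8.17%. Compound 3 (`O=C(CCCCC(S)CCS)Nc1ccccc1`) gives 7.37%. For the measured compounds named here, these are the only two numbers, and they lie within the scatter of each other, so compound 3 stands level with compound 2.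

Compound 4 (`O=C(CCCCC(S)CCS)Nc1ccccc1Cl`) is compound 3 with chloro in place of hydrogen on an aromatic carbon, ortho to a large group: chloro in place of hydrogen on an aromatic carbon. Going by the values given here, no measured pair isolates this change. Compound 2, which also carries a chloro, gives 8.17%, within the scatter of compound 3 at 7.37%. On that evidence, no step beyond the scatter is expected in this assay, in either direction. The estimated change is a number 0.6 percentage points higher from compound 3 to compound 4 (within the scatter). For compound 4 the expected value is 8%, with an estimated range of 2% to 15%.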

Compound 4, percent growth inhibition at one concentration: 6.11%
For compound 4 the middle estimate is 1.9 percentage points above the measured one; measured number inside the range.
By their numbers in this assay, from the lowest: compounds 4, 3 and 2 (each within the scatter of the next).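

In this assay chloro in place of hydrogen on an aromatic carbon, ortho to a large group, now has a pair of its own (a number 1.3 percentage points lower from compound 3 to compound 4 (within the scatter)), so at this position the change cannot be told apart from the scatter. With the chloro held in place, the open-chain group of 5 heavy atoms and the group holding one five-membered non-aromatic ring with 2 hetero atoms, on a saturated chain carbon, also stand level (a number 2.1 percentage points lower from compound 2 to compound 4 (within the scatter)). No measurement is available that bears on these results.

Going by these compounds, whether a methoxy, a nitrile or an amine on the same aromatic carbon would give a step beyond the scatter remains open. On these data alone, a longer chain in place of the present one is equally open.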